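The source may hold more compounds than are shown below. What is called first, only, known or untested is meant among the compounds shown, and "the series" means these compounds.

Measured so far:

compound 1 `CCC(CCO)n1cnc2c(Cl)ncnc21` — > 50000 nM
compound 2 `CCCCCCCC(CCO)n1cnc2c(Cl)nc(F)nc21` — 17600 nM
compound 3 `CCCCCCCCCC(CCO)n1cnc2c(Cl)ncnc21` — 890 nM

All three were run in a functional assay on HCT-116 cells (Homo sapiens) for antiproliferative activity, read by MTT assay, with a stated time of 48 h; a lower number here means a stronger inhibitor, a higher number a weaker inhibitor. Compound 3 gives 890 nM in this assay. Compound 2 gives 17600 nM in this assay, the higher of the two numbers; the difference between the cores of compound 2 and compound 3 is not broken down here. For compound 1 the value in this assay is a limit, not a number: > 50000 nM.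

Going by the values given here, the one change measured in this assay is hydrogen in place of heptyl on a saturated chain carbon, three bonds along the chain from an aromatic nitrogen, which gives an at least 56-fold higher number from compound 3 to compound 1 (1.74 log units; beyond the scatter). The step can only be read as a lower bound because of the limit of > 50000 nM in this assay, at which 1 of the 3 values shown sits.

Compound 4 `OCCCn1cnc2c(Cl)nc(F)nc21` has not yet been run in this assay. It differs from compound 2 by hydrogen in place of heptyl on a saturated chain carbon bound to an aromatic nitrogen and a saturated chain carbon. This is the same kind of change as that from compound 3 to compound 1, though not the same: there the heptyl sat on a saturated chain carbon three bonds along the chain from an aromatic nitrogen, here it sits on a saturated chain carbon bound to an aromatic nitrogen and a saturated chain carbon. Since compound 2 already starts from 17600 nM and the earlier removal of heptyl gave an at least 56-fold higher number from compound 3 to compound 1 (1.74 log units; beyond the scatter), the expected step is an 8.5-fold higher number from compound 2 to compound 4 (0.93 log units; beyond the scatter). Compound 4 is therefore expected to give about 150000 nM in this assay, between 30000 nM and 800000 nM, and most likely only a limit will be reported.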

Compound 4, half-maximal inhibitory concentration: 39800 nM
Estimate against measurement, compound 4: 3.8-fold (0.58 log units) above, within the range that was stated.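

In this assay, hydrogen in place of heptyl gives a 2.3-fold higher number from compound 2 to compound 4 (0.35 log units; beyond the scatter), so the change points the same way on both cores but its size does not carry over: the same change on two cores in this assay, an at least 56-fold higher number (1.74 log units; beyond the scatter) from compound 3 to compound 1 and a 2.3-fold higher number (0.35 log units; beyond the scatter) from compound 2 to compound 4, at least 24-fold (1.39 log units) apart, beyond the scatter of two such steps. The earlier step can be read only as a lower bound, as compound 1 stands at a limit of the assay: the limit of > 50000 nM in this assay, at which 1 of the 4 values shown sits. What this does not show is that the core alone sets the size of the step: the heptyl sits on a saturated chain carbon three bonds along the chain from an aromatic nitrogen in one pair and on a saturated chain carbon bound to an aromatic nitrogen and a saturated chain carbon in the other, so core and place are not separated.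

The compounds shown leave open what the same change gives when its place is held constant on both cores. They also leave open how the number in this assay responds to a longer chain on the same carbon, or to an amine or a carboxylic acid in place of the hydroxyl group.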